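The source may report more compounds than this note shows. Statements on the series, on what has been measured and on what is new or still open speak of the compounds shown alone.

Within the data shown here, in a functional assay on B16 cells (Mus musculus) for cytotoxicity, read by MTT assay, with a stated time of 48 h (a lower number here means a stronger inhibitor, a higher number a weaker inhibitor), compound 1 (`C=C1CCC[C@]2(C)CCC(c3cn(-c4ccc(C(C)=O)cc4)nn3)=CC[C@@]12C`) gives 61000 nM and compound 2 (`C=C1CCC[C@]2(C)CCC(c3cn(-c4cccc([N+](=O)[O-])c4)nn3)=CC[C@@]12C`) gives 31700 nM, so compound 2 stands within the scatter of the only other measured compound. Compound 3 (`C=C1CCC[C@]2(C)CCC(c3cn(-c4ccc(I)cc4)nn3)=CC[C@@]12C`) has 4-iodophenyl in place of 3-nitrophenyl on an aromatic nitrogen. Among the measured compounds shown here, one measured step bears on this change, a swap on the same aromatic nitrogen: a 1.9-fold lower number from compound 1 to compound 2 (0.28 log units; within the scatter). For the measured compounds named here, with only that small step as a guide, no step beyond the scatter is expected in this assay, in either direction. The estimated step is a 1.1-fold higher number from compound 2 to compound 3 (0.04 log units; within the scatter). For compound 3 the expected value is 35000 nM, with an estimated range of 14000 nM to 85000 nM.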

Compound 3, half-maximal inhibitory concentration: 144000 nM
Compound 3: middle estimate off by 4.1-fold (0.61 log units), on the low side; the whole stated range lies below it.
By their numbers in this assay, from the lowest: compounds 2 and 1 (each within the scatter of the next); then compound 3.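

In this assay the swap on this aromatic nitrogen now gives a change beyond the scatter (a 4.5-fold higher number from compound 2 to compound 3 (0.66 log units; beyond the scatter)), which the earlier pair did not show. Iodo in place of acetyl on an aromatic carbon also gives a change beyond the scatter (a 2.4-fold higher number from compound 1 to compound 3 (0.37 log units; beyond the scatter)), so compound 3 is the weakest of the three. Nothing shown here accounts for these differences. Still open, going by these compounds, is how much of the step from compound 2 comes from the group and how much from its ring position, since 3-nitrophenyl and 4-iodophenyl differ in both. Also open, on these data alone, is where a phenyl bearing an amine or a carboxylic acid would fall.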